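Series notes: aza-indazole fused core, five-membered ring swap

The source may report more compounds than this note shows. Statements on the series, on what has been measured and on what is new or still open speak of the compounds shown alone.

Two compounds carry numbers in a functional assay (aorta) with Oryctolagus cuniculus as the target; on this read-out lower numbers stand for stronger inhibition and higher numbers for weaker inhibition. Compound 1 `OCc1ccc(-c2nn(Cc3cncnc3)c3ccccc23)o1` gives 3200 nM. Compound 2 `Cc1oc(-c2nn(Cc3ccccc3F)c3ncccc23)nc1CO` gives 1500 nM, the lower of the two values, and the gap to compound 1 lies beyond the scatter of repeat measurements. Compound 3 `Fc1ccccc1Cn1nc(-c2cc[nH]n2)c2cccnc21` differs from compound 2 in one place: 1H-pyrazol-3-yl in place of 4-(hydroxymethyl)-5-methyl-1,3-oxazol-2-yl on an aromatic carbon. Among the measured compounds shown here, no step between measured compounds covers such a change; the only guidance is that both measured compounds carry a hydroxymethyl group. A modest loss of inhibition is therefore expected, a 2.3-fold higher number from compound 2 to compound 3 (0.37 log units; beyond the scatter). For compound 3 the estimate in this assay is 3500 nM, with a range from 900 nM to 14000 nM.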

Compound 3, half-maximal inhibitory concentration: 1800 nM
Estimate against measurement, compound 3: 1.9-fold (0.29 log units) above; the range from low to high includes it.
By their numbers in this assay, from the lowest: compounds 2, 3 and 1 (each within the scatter of the next, the first and the last beyond it).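

In this assay, 1H-pyrazol-3-yl in place of 4-(hydroxymethyl)-5-methyl-1,3-oxazol-2-yl on this aromatic carbon gives a 1.2-fold higher number from compound 2 to compound 3 (0.08 log units; within the scatter). In this pair, then, the smaller ring without hydroxymethyl or methyl groups holds the read-out, so neither group is required at this position for this level of inhibition. Nothing on hand explains this outcome.

Open, from the compounds shown here alone, is whether a carboxylic acid or an amine on this aromatic carbon would move the number in this assay beyond the scatter. Also open, going by these compounds, is whether the 1H-pyrazol-3-yl result carries over when the 2-fluorobenzyl group is changed.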